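Swapping the Ethynylphenyl Group: Clearance Outlook for Compound 4

The compounds below may be only part of what the source reports. "The series", "measured", "known", "first", "only" and "open" are said of these compounds alone.

Compound 1 `CC1SC(c2cccc(C(=O)NCCCCc3ccccc3)c2)N(c2ccc(C3CC3)cc2)C1=O` — 3210 mL.min-1.g-1
Compound 2 `O=C(NCCCCc1ccccc1)c1cccc(C2SCC(=O)N2c2ccccn2)c1` — 644 mL.min-1.g-1
Compound 3 `C#Cc1cccc(N2C(=O)CSC2c2cccc(C(=O)NCCCCc3ccccc3)c2)c1` — 1900 mL.min-1.g-1

All three numbers come from an ADME assay on microsomes from liver (Mus musculus) for metabolic stability, read by LC-MS, using NADPH, with a stated time of 10 min, tested at 0.1 uM (a lower number here means slower removal, a higher number faster removal of the compound), and the three compounds share one core, differing only in the group on the amide-type nitrogen in the ring. Compound 3 stands second highest of the three: its nearest neighbour is compound 1, a gap that sits within the scatter, and its furthest is compound 2, a gap that lies beyond the scatter.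

The next compound, compound 4 `O=C(NCCCCc1ccccc1)c1cccc(C2SCC(=O)N2c2ccc(C3CC3)cc2)c1`, has not yet been measured. It differs from compound 3 in one place: 4-cyclopropylphenyl in place of 3-ethynylphenyl on an amide-type nitrogen in a ring

Within the data shown here, only one measured step touches this position, a 3.0-fold higher number from compound 2 to compound 3 (0.47 log units; beyond the scatter), and it changes a different pair of groups, so it gives the size of a change at this spot rather than a direct forecast. More telling is compound 1, which carries the same 4-cyclopropylphenyl group together with an extra methyl group and gives 3210 mL.min-1.g-1.

Compound 4 is therefore expected to move by a 1.4-fold higher number from compound 3 to compound 4 (0.14 log units; within the scatter), a shift within the scatter. The estimated clearance of compound 4 is 2600 mL.min-1.g-1, with a range of 1300 mL.min-1.g-1 to 5200 mL.min-1.g-1.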

Compound 4, intrinsic clearance in microsomes: 2960 mL.min-1.g-1
Estimate against measurement, compound 4: 1.1-fold (0.06 log units) below, and the stated range covers the measured number.
By their numbers in this assay, from the lowest: compound 2; then compounds 3, 4 and 1 (each within the scatter of the next).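

The step of a 1.6-fold higher number from compound 3 to compound 4 (0.19 log units; within the scatter) shows that 4-cyclopropylphenyl and 3-ethynylphenyl cannot be told apart at this position, although one brings a three-membered ring and the other a triple bond. The step of a 4.6-fold higher number from compound 2 to compound 4 (0.66 log units; beyond the scatter) is wider and, read together with a 3.0-fold higher number from compound 2 to compound 3 (0.47 log units; beyond the scatter), it sets pyridin-2-yl apart from two different groups built on an aromatic ring of carbon only, where a single step could show the gap for just one such group. The step of a 1.1-fold lower number from compound 1 to compound 4 (0.04 log units; within the scatter) adds that removing the methyl on the saturated ring carbon leaves a difference that cannot be separated from the scatter, so this methyl does not account for where compound 1 stands.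

Nothing shown here explains why the compound with pyridin-2-yl stands apart from the other two at this position. From the compounds shown here alone, it also remains open whether a pyridin-3-yl group, or a phenyl ring carrying an amine or a carboxylic acid, would sit with compound 2 or with compound 3 and compound 4.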